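Exchanging the aryl on the urea nitrogen of compound 3

This account rests on a few compounds, and the source may have more. Where it says the series, first, only, none or still open, it means among the compounds named here.

Among the three measured compounds, compound 3 `COc1ccc(NC(=O)Nc2cccc(-c3nc(-c4ccc(NC(=O)c5cccnc5)cc4Cl)no3)c2)cc1C(F)(F)F` is the only one with a number: in a functional assay on MDA-MB-231 cells (Homo sapiens) for antiproliferative activity, read by MTT assay, with a stated time of 72 h (on this read-out higher numbers stand for weaker inhibition and lower numbers for stronger inhibition), compound 3 gives 1700 nM. Compound 1 `O=C(Nc1ccc(Cl)cc1)Nc1cccc(-c2nc(-c3ccc(NC(=O)c4cccnc4)cc3Cl)no2)c1` reaches only a limit, > 10000 nM. Compound 2 `NS(=O)(=O)c1ccc(NC(=O)Nc2cccc(-c3nc(-c4ccc(NC(=O)c5cccnc5)cc4Cl)no3)c2)cc1` likewise sits at a limit, > 10000 nM. The step between compound 1 and compound 2 is a step that the two limits leave unreadable from compound 1 to compound 2. Two steps are large: an at least 5.8-fold lower number from compound 1 to compound 3 (0.76 log units; beyond the scatter) and an at least 5.8-fold lower number from compound 2 to compound 3 (0.76 log units; beyond the scatter), each moving away from the limit of > 10000 nM in this assay, at which 2 of the 3 values shown sit. Compound 4 `CS(=O)(=O)Nc1cccc(NC(=O)Nc2cccc(-c3nc(-c4ccc(NC(=O)c5cccnc5)cc4Cl)no3)c2)c1` carries the change (3-(methanesulfonamido)phenyl in place of 4-methoxy-3-(trifluoromethyl)phenyl on an amide-type nitrogen). This removes the group that set compound 3 apart and brings in a phenyl bearing a sulfonamide, closer in kind to compound 2, so a step back toward weaker inhibition in this assay is expected, a 4.7-fold higher number from compound 3 to compound 4 (0.67 log units; beyond the scatter). Compound 4 is therefore estimated at 8000 nM, within 2500 nM to 20000 nM.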

Compound 4, half-maximal inhibitory concentration: > 10000 nM
Compound 4: a limit, no number; the forecaster's own chance of this, stated with the estimate: 50%; middle value at least 1.2-fold (0.09 log units) away from the limit.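

In this assay, putting 3-(methanesulfonamido)phenyl in place of 4-methoxy-3-(trifluoromethyl)phenyl on the amide-type nitrogen gives an at least 5.8-fold higher number from compound 3 to compound 4 (0.76 log units; beyond the scatter) and so a third aryl here falls short of compound 3. Among the four compounds, only 4-methoxy-3-(trifluoromethyl)phenyl on this nitrogen yields a number. The steps among compound 1, compound 2 and compound 4 cannot be read, as each compound stands at a limit: the limit of > 10000 nM in this assay, at which 3 of the 4 values shown sit. As far as these compounds go, whether a phenyl bearing only the methoxy or only the trifluoromethyl would yield a number stays open. So does the effect of an amine or a carboxylic acid on this phenyl.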